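Replacing Cyclopropyl with 2-Methoxyphenyl on Compound 3

A few compounds are considered here, and "the series" means these few. Any claim that something is new, unique, unknown or untested is made for them only; others in the source may bear on it.

Going by the values given here, compound 3 `O=C(O)c1ccccc1-c1ccc(CCc2ncc(CC3CC3)[nH]2)cc1` gives 72 nM in an in vitro functional assay on cells for agonist activity at Bombesin receptor subtype-3 (Mus musculus), read by luminescence and calcium flux (a lower number here means that less compound is needed, a higher number that more compound is needed for the effect), the highest of the three numbers so far; its nearest neighbour is compound 2 `O=C(O)c1ccccc1-c1ccc(CCc2ncc(CC3CCCC3)[nH]2)cc1` with 7.9 nM, and compound 1 `O=C(O)c1ccccc1-c1ccc(CCc2ncc(CC3CCCCC3)[nH]2)cc1` gives 7.3 nM. Compound 4 `COc1ccccc1Cc1cnc(CCc2ccc(-c3ccccc3C(=O)O)cc2)[nH]1` differs from compound 3 by 2-methoxyphenyl in place of cyclopropyl on a saturated chain carbon bound to an aromatic carbon. Among the compounds with values here, the steps that bear on this change are a 9.9-fold higher number from compound 1 to compound 3 (0.99 log units; beyond the scatter) and a 9.1-fold higher number from compound 2 to compound 3 (0.96 log units; beyond the scatter), both showing that a small ring at this position goes with a higher number, while a 1.1-fold higher number from compound 1 to compound 2 (0.03 log units; within the scatter) shows little between the two larger rings. A larger group entering at the same place is therefore expected to give a lower number, with compound 4 estimated at 12 nM in this assay, between 3 nM and 50 nM, a step of a 6.0-fold lower number from compound 3 to compound 4 (0.78 log units; beyond the scatter).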

Compound 4, half-maximal effective concentration: 163 nM
For compound 4 the middle estimate is 14-fold (1.13 log units) below the measured one, and the stated range ends below it.
By their numbers in this assay, from the lowest: compounds 1 and 2 (each within the scatter of the next); then compound 3; then compound 4.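

Larger is not simply better at this position: in this assay 2-methoxyphenyl, the largest group, brings a 2.3-fold higher number from compound 3 to compound 4 (0.35 log units; beyond the scatter) instead of continuing the trend of the saturated rings. Against the larger rings the change is wider, with a 21-fold higher number from compound 2 to compound 4 (1.31 log units; beyond the scatter) and a 22-fold higher number from compound 1 to compound 4 (1.35 log units; beyond the scatter) (both large), so compound 4 has the highest number of the four. Nothing available here accounts for this result. From the compounds shown here alone, whether the aromatic ring or its methoxy goes with the higher number remains open. Plain phenyl or methoxycyclohexyl at this place would separate the two.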